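The compounds below may be only part of what the source reports. "The series", "measured", "known", "first", "only" and "open" are said of these compounds alone.

In an ADME assay on microsomes from liver (Canis lupus familiaris) for metabolic stability, read by LC-MS, using NADPH, with a stated time of 10 min, tested at 0.1 uM (on this read-out lower numbers stand for slow clearance and higher numbers for fast clearance), compound 1 `CC1SC(c2cccc(C(=O)NCCCCc3ccccc3)c2)N(c2ccc(C3CC3)cc2)C1=O` gives 1750 mL.min-1.g-1, the highest of the two numbers shown, while compound 2 `O=C(NCCCCc1ccccc1)c1cccc(C2SCC(=O)N2c2cccc(-c3c[nH]nn3)c2)c1` gives 226 mL.min-1.g-1, a lower number that lies beyond the scatter. Compound 3 `COc1ccccc1N1C(=O)C(C)SC1c1cccc(C(=O)NCCCCc2ccccc2)c1` remains unmeasured. It differs from compound 1 by 2-methoxyphenyl in place of 4-cyclopropylphenyl on an amide-type nitrogen in a ring. Going by the values given here, no step between measured compounds covers this change, so the expectation rests on compound 1 alone. The step of a 1.9-fold lower number from compound 1 to compound 3 (0.29 log units; within the scatter) is expected to be a modest fall, close to the edge of the scatter. Compound 3 is accordingly estimated at 900 mL.min-1.g-1, within a range from 300 mL.min-1.g-1 to 2500 mL.min-1.g-1.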

Compound 3, intrinsic clearance in microsomes in the Canis lupus familiaris assay: 1170 mL.min-1.g-1
Compound 3: middle estimate off by 1.3-fold (0.11 log units), on the low side, and the stated range covers the measured number.
By their numbers in the Canis lupus familiaris assay, from the lowest: compound 2; then compounds 3 and 1 (each within the scatter of the next).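

In the Canis lupus familiaris assay, 2-methoxyphenyl in place of 4-cyclopropylphenyl on the amide-type nitrogen in the ring gives a 1.5-fold lower number from compound 1 to compound 3 (0.17 log units; within the scatter), so this change leaves the clearance within the scatter. In a physicochemical assay for solubility, read by turbidimetry, measured as kinetic solubility, at pH 6.8 (a lower number here means a less soluble compound, a higher number a more soluble compound), compound 1 gives 10000 nM and compound 3 gives 20000 nM, two values within the scatter of each other. Nothing measured here offers a reason for either result. The compounds shown leave open whether a carboxylic acid or an amine at this nitrogen, in place of 2-methoxyphenyl, would take the clearance beyond the scatter.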